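The compounds below may be only part of what the source reports. "The series", "measured", "known", "first", "only" and "open" are said of these compounds alone.

Compound 1 `O=c1nc2oc(CCCCl)cc2cn1Cc1cn(Cc2ccccc2)nn1`, compound 2 `O=c1nc2oc(CCCCl)cc2cn1Cc1cn(-c2ccc(Cl)cc2)nn1` and compound 3 `O=c1nc2oc(C3CC3)cc2cn1Cc1cn(-c2ccc(Cl)cc2)nn1` were each tested in a functional assay on A549 cells (Homo sapiens) for antiproliferative activity, read by MTT assay, with a stated time of 72 h; a lower number here means a stronger inhibitor, a higher number a weaker inhibitor. In this assay compound 1 gives 27900 nM, compound 2 gives 52000 nM and compound 3 gives 61000 nM. Compound 4 `O=c1nc2oc(C3CC3)cc2cn1Cc1cn(Cc2ccccc2)nn1` has not been measured yet. It differs from compound 3 by benzyl in place of 4-chlorophenyl on an aromatic nitrogen. The same change has been made once before, from compound 2 to compound 1 (benzyl in place of 4-chlorophenyl on an aromatic nitrogen), where it produced a 1.9-fold lower number from compound 2 to compound 1 (0.27 log units; within the scatter). The place of the change reads the same in both pairs, so it is the same change. The cores of compound 2 and compound 3 differ by cyclopropyl in place of 3-chloropropyl on an aromatic carbon, a change that produced a 1.2-fold higher number from compound 2 to compound 3 (0.07 log units; within the scatter). A step of similar size is expected from compound 3 to compound 4, namely a 1.7-fold lower number from compound 3 to compound 4 (0.24 log units; within the scatter), because the earlier step of a 1.9-fold lower number from compound 2 to compound 1 (0.27 log units; within the scatter) was of that size. This expectation rests on a single earlier pair, so it is held loosely. Compound 4 is expected to give about 35000 nM in this assay, most likely between 15000 nM and 80000 nM.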

Compound 4, half-maximal inhibitory concentration: 45000 nM
For compound 4 the middle estimate is 1.3-fold (0.11 log units) below the measured one, within the range that was stated.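

In this assay, benzyl in place of 4-chlorophenyl gives a 1.4-fold lower number from compound 3 to compound 4 (0.13 log units; within the scatter), and this step carries over from one core to the other: the same change on two cores in this assay, a 1.9-fold lower number (0.27 log units; within the scatter) from compound 2 to compound 1 and a 1.4-fold lower number (0.13 log units; within the scatter) from compound 3 to compound 4, 1.4-fold (0.14 log units) apart, within the scatter of two such steps. Cyclopropyl in place of 3-chloropropyl gives a 1.6-fold higher number from compound 1 to compound 4 (0.21 log units; within the scatter), and this step carries over in the same way: the same change on two cores in this assay, a 1.2-fold higher number (0.07 log units; within the scatter) from compound 2 to compound 3 and a 1.6-fold higher number (0.21 log units; within the scatter) from compound 1 to compound 4, 1.4-fold (0.14 log units) apart, within the scatter of two such steps. Among the compounds shown here, each single change therefore behaves alike on both cores, but every step lies within the scatter, so this shows only that neither change moved the number by more than repeated measurements might, not that either has a real effect of a set size or direction, and two cores are too few for a general rule.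

Going by these compounds, it remains open whether a group of another kind, such as an amine or a carboxylic acid in place of the benzyl, or a longer chain in place of the 3-chloropropyl, would shift the number beyond the scatter. On these data alone, it also remains open whether the two changes would behave alike on other cores.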